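A triazole in place of an ethyl chain

The source may report more compounds than this note shows. Statements on the series, on what has been measured and on what is new or still open speak of the compounds shown alone.

Compound 1 `CCC(=O)N1CCC(C(=O)N2N=CCC2c2ccccc2)CC1` was examined in an ADME assay on microsomes (Rattus norvegicus) for metabolic stability (a higher number here means that the compound lasts longer, a lower number that the compound disappears faster), where compound 1 gives 1.07 h. Of the two numbers reported, that of compound 1 is the lower, though the gap to compound 2 `CC(C)(C)C(=O)N1N=CCC1c1ccccn1`, which gives 1.32 h, lies within the usual scatter. Compound 3 `CC(C)(C)C(=O)N1N=CCC1C1CCCCC1` gives < 0.0234 h, which is the limit of < 0.0234 h in this assay, at which 1 of the 3 values shown sits, and not a number. Compound 4 `O=C(c1c[nH]nn1)N1CCC(C(=O)N2N=CCC2c2ccccc2)CC1` has not yet been measured. It differs from compound 1 in one place, (1H-1,2,3-triazol-4-yl in place of ethyl on a carbonyl carbon), or, read one bond further out, (1H-1,2,3-triazol-4-yl)carbonyl in place of propanoyl. Among the compounds with values here, no step between measured compounds shows what this change does in this assay. Compound 4 is therefore expected to give about 1.5 h, with a range from 0.5 h to 4.5 h. The expected step of a 1.4-fold higher number from compound 1 to compound 4 (0.15 log units; within the scatter) would stay within the scatter.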

Compound 4, half-life: > 2.75 h
Compound 4: no number, only a limit (the forecaster's own chance of this, stated with the estimate: 5%); middle value at least 1.8-fold (0.26 log units) from the limit.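

In this assay, within the data shown here, 1H-1,2,3-triazol-4-yl in place of ethyl on a carbonyl carbon gives an at least 2.5-fold higher number from compound 1 to compound 4 (0.40 log units; beyond the scatter), the only step read so far at this position. It shows that this position accepts a five-membered aromatic ring with 3 hetero atoms with no loss of half-life. Compound 4 gives a limit and not a number, so the full size of the step stays unknown: the limit of > 2.75 h in this assay, at which 1 of the 4 values shown sits.

The compounds shown leave open whether another ring, such as phenyl, or a longer chain would give a similar step. They also leave open whether the triazole would keep it with a methyl group on its ring nitrogen.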